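Carbamoyl to carboxy: working notes on the series

The source may hold more compounds than are shown below. What is called first, only, known or untested is meant among the compounds shown, and "the series" means these compounds.

Within the data shown here, in an ADME assay on HEL cells (Homo sapiens) for inhibition (on this read-out higher numbers stand for lower toxicity in this test and lower numbers for higher toxicity in this test), three compounds carry numbers so far. Compound 1 `CCCCCc1ccc(-c2cc3cn([C@H]4C[C@H](OC(=O)[C@@H](NC(=O)[C@@H]5CCCN5C(=O)[C@@H](N)C(C)C)C(C)C)[C@@H](CO)O4)c(=O)nc3o2)cc1` gives 17000 nM on this read-out. Compound 2 `CCCCCc1ccc(-c2cc3cn([C@H]4C[C@H](O)[C@@H](COC(=O)[C@H](C)NC(=O)[C@@H]5CCCN5C(=O)[C@@H](N)C(C)C)O4)c(=O)nc3o2)cc1` gives 44000 nM on the same read-out. Compound 3 `CCCCCc1ccc(-c2cc3cn([C@H]4C[C@H](O)[C@@H](COC(=O)[C@@H](NC(=O)[C@@H]5CCCN5C(=O)[C@@H](N)CC(N)=O)C(C)C)O4)c(=O)nc3o2)cc1` gives 56000 nM and so sits level with compound 2 within the scatter, while its gap to compound 1 lies beyond the scatter.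

Compound 4 `CCCCCc1ccc(-c2cc3cn([C@H]4C[C@H](O)[C@@H](COC(=O)[C@@H](NC(=O)[C@@H]5CCCN5C(=O)[C@@H](N)CC(=O)O)C(C)C)O4)c(=O)nc3o2)cc1` keeps the whole of compound 3 except for one group. The change is hydroxy in place of amino on a carbonyl carbon and it can also be read as carbamoyl to carboxy.

Among the measured compounds shown here, no two measured compounds differ in one place only, so the series offers no direct precedent for this change in this assay and no firm direction can be drawn from it. The expectation rests on compound 3 at 56000 nM as the closest measured structure, and no step beyond the scatter is expected. The estimated step of a 1.1-fold higher number from compound 3 to compound 4 (0.03 log units; within the scatter) is expected to stay inside the scatter. Compound 4 is estimated at 60000 nM with an expected range from 28000 nM to 130000 nM on this read-out.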

Compound 4, half-maximal cytotoxic concentration in the HEL assay: 52000 nM
Beside the measured number, compound 4's estimate is 1.2-fold (0.06 log units) above it; the range from low to high includes it.
By their numbers in the HEL assay, from the lowest: compound 1; then compounds 2, 4 and 3 (each within the scatter of the next).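

In the HEL assay, the series now has its first comparison of compounds that differ in one place, a 1.1-fold lower number from compound 3 to compound 4 (0.03 log units; within the scatter), so at this position hydroxy in place of amino on a carbonyl carbon, which also reads as carbamoyl to carboxy, leaves the number level within the scatter. The same change does register in a physicochemical assay for solubility, with a stated time of 24 h (a higher number here means a more soluble compound, a lower number a less soluble compound), where the number falls by more than the scatter: the measured solubility of compound 3, 39000 ug/mL, and of compound 4, 15000 ug/mL, a 2.6-fold lower number (0.41 log units; beyond the scatter) In the physicochemical assay compound 3 gives 39000 ug/mL and compound 4 gives 15000 ug/mL. The two read-outs therefore part at this position, with the change visible in solubility but not in the cell read-out, a finding that rests on this single pair and claims no pattern for the series.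

From the compounds shown here alone, it remains open whether a methyl ester or a dimethylamide on the same carbonyl carbon would also stay level in the HEL assay, and where either would fall in the physicochemical assay. Going by these compounds, it is also open whether carbamoyl to carboxy would give the same two results on a longer chain, such as carbamoylethyl to carboxyethyl, or at another place on the shared core.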